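The source may hold more compounds than are shown below. What is called first, only, known or untested is meant among the compounds shown, and "the series" means these compounds.

Measured so far in a functional assay on cells (Peritoneal macrophage, Mus musculus) for cytotoxicity, with a stated time of 24 h; on this read-out lower numbers stand for higher toxicity in this test and higher numbers for lower toxicity in this test:

compound 1, `COc1ccc(S(=O)(=O)N(CC(N)=O)c2ccc(N(CC(N)=O)S(=O)(=O)c3ccc(NC(C)=O)cc3)c3ccccc23)cc1`, gives > 50000 nM
compound 2, `CCC(=O)Nc1ccc(S(=O)(=O)N(CC(N)=O)c2ccc(N(CC(N)=O)S(=O)(=O)c3ccc(OC)cc3)c3ccccc23)cc1`, gives > 50000 nM
compound 3, `COc1ccc(S(=O)(=O)N(CC(N)=O)c2ccc(N(CC(N)=O)S(=O)(=O)c3ccc(NC(=O)CCN4CCCCC4)cc3)c3ccccc23)cc1`, gives > 100000 nM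

Each of these three values is a limit of this assay, not a number. For compound 2 the value > 50000 nM is a limit. For compound 1 the value > 50000 nM is also a limit. For compound 3 the value > 100000 nM is a limit as well. Compound 2 therefore stands at the limit of > 50000 nM in this assay, at which 2 of the 3 values shown sit, while the limit of > 100000 nM in this assay, at which 1 of the 3 values shown sits, holds the remaining value, and none of the three can be ranked against the others.

Compound 4, `COc1ccc(S(=O)(=O)N(CC(N)=O)c2ccc(N(CC(N)=O)S(=O)(=O)c3ccc(NC(=O)CCCN4CCN(C(C)C)CC4)cc3)c3ccccc23)cc1`, differs from compound 2 by (4-isopropylpiperazin-1-yl)methyl in place of hydrogen on a saturated chain carbon, two bonds along the chain from a carbonyl carbon. The closest measured comparison is the change of a step that the two limits leave unreadable from compound 2 to compound 3, and the related changes a step that the two limits leave unreadable from compound 1 to compound 2 and a step that the two limits leave unreadable from compound 1 to compound 3 are likewise unreadable between limits. For the measured compounds named here, no step in this assay has been read as a number, so no direction beyond the scatter can be expected for the step from compound 2 to compound 4.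

The estimate for compound 4 is therefore 80000 nM, within 30000 nM to 300000 nM, most likely again reported as a limit, meaning an expected step that the limit leaves unreadable from compound 2 to compound 4.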

Compound 4, half-maximal cytotoxic concentration: > 100000 nM
Compound 4: no number, only a limit (the forecaster's own chance of this, stated with the estimate: 80%); at least 1.2-fold (0.09 log units) between middle value and limit.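

In this assay compound 4 gives > 100000 nM, which is a limit and not a number. Its steps from compound 1, compound 2 and compound 3 therefore cannot be read. The compounds shown leave open the actual toxic concentration of each compound, and whether changing the side chain alters it.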